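Working notes on a corticotropin-releasing factor receptor series

The source may hold more compounds than are shown below. What is called first, only, known or untested is meant among the compounds shown, and "the series" means these compounds.

Measured so far:
compound 1 `COc1nc(C)c(Nc2nc(Cl)cn([C@H](C)C3CC3)c2=O)cc1C`: 1.5 nM
compound 2 `CC[C@H](C1CC1)n1cc(C#N)nc(Nc2cc(C)c(OC)nc2C)c1=O`: 1.7 nM

In an assay on frontal cortex for displacement of a labelled ligand from corticotropin-releasing factor receptor 1 (Rattus norvegicus) (on this read-out lower numbers stand for stronger inhibition and higher numbers for weaker inhibition), compound 1 gives 1.5 nM and compound 2 gives 1.7 nM. Compound 2 holds the higher of the two numbers, but its nearest neighbour, compound 1, lies within the usual scatter of it, so the two cannot be told apart and no ranking between them is claimed. Among the compounds with values here, no pair of measured compounds differing in a single place is available here; compound 1 and compound 2 differ in more than one place.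

Compound 3 `COc1nc(C)c(Nc2nc(C#N)cn([C@H](C)C3CC3)c2=O)cc1C` has yet to be measured. Against compound 2 it carries the change (hydrogen in place of methyl on a saturated chain carbon, two bonds along the chain from an aromatic nitrogen and a saturated ring carbon); cut one bond further out, the same difference reads ethyl to methyl, or 1-cyclopropylpropyl to 1-cyclopropylethyl. Within the data shown here, nothing measured so far fixes the size of such a step. The expectation is a step from compound 2 to compound 3 of a 1.1-fold lower number from compound 2 to compound 3 (0.03 log units; within the scatter), none beyond the scatter, since the 1-cyclopropylethyl-bearing compound 1 gives 1.5 nM in this assay. Compound 3 is therefore estimated at about 1.6 nM, within 0.7 nM to 4 nM.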

Compound 3, half-maximal inhibitory concentration: 10 nM
Compound 3: middle estimate off by 6.3-fold (0.80 log units), on the low side; measured number above the stated range.
By their numbers in this assay, from the lowest: compounds 1 and 2 (each within the scatter of the next); then compound 3.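

In this assay the methyl on the saturated chain carbon proves not to be neutral: with the nitrile held constant, hydrogen in place of methyl gives a 5.9-fold higher number from compound 2 to compound 3 (0.77 log units; beyond the scatter) and shows that this position responds to the loss of a single carbon. With the 1-cyclopropylethyl group held constant, cyano in place of chloro on the aromatic carbon gives a 6.7-fold higher number from compound 1 to compound 3 (0.82 log units; beyond the scatter) and shows that the aromatic position responds as well. Within the data shown here, compound 1 and compound 2 each carry a different pairing of these groups and gave no sign of either step, so neither group can be judged apart from the other, and each step is known on one background only.

No measurement available speaks to the origin of either step.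

On these data alone, whether the change from 1-cyclopropylpropyl to 1-cyclopropylethyl keeps its size with chloro on the aromatic carbon remains open. Also open, as far as these compounds go, is how a longer chain such as 1-cyclopropylbutyl, or a bromo or methoxy group on the aromatic carbon, would read in this assay on the shared core.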